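Toward an isopropyl amide of compound 1

This account rests on a few compounds, and the source may have more. Where it says the series, first, only, none or still open, it means among the compounds named here.

Compound 1 `COc1cc2c(cc1OC)C(CC(=O)O)CC2` and compound 3 `CCCNC(=O)CC1CCc2cc(OC)c(OC)cc21` together hold the low end of three numbers in a functional assay on the whole organism (strain Wistar) for inhibition, with Rattus norvegicus as the target, read by paw edema, with stated times of 60 min and 1 h, at a dose of 100 mg/kg by the oral route; a higher number here means more inhibition at the dose given (going by the name of the read-out), a lower number less inhibition: compound 1 gives 18.8% and compound 3 gives 18.8%, with no change at the digits printed from compound 1 to compound 3 (within the scatter). Compound 2 `CCN(CC)C(=O)CC1CCc2cc(OC)c(OC)cc21`, carrying diethylamino at the same place, gives 31.3%, a gain of a number 12.5 percentage points higher from compound 1 to compound 2 (beyond the scatter), matched by a number 12.5 percentage points lower from compound 2 to compound 3 (beyond the scatter). Compound 4 `COc1cc2c(cc1OC)C(CC(=O)NC(C)C)CC2` differs from compound 1 in one place: isopropylamino in place of hydroxy on a carbonyl carbon. The step to compound 3, where propylamino replaced hydroxy, bears most on it and showed no change at the digits printed from compound 1 to compound 3 (within the scatter); only diethylamino moved the number. Compound 4 is therefore expected to show a number 1.2 percentage points higher from compound 1 to compound 4 (within the scatter), nothing beyond the scatter. Compound 4 is estimated at 20% in this assay, between 9% and 32%.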

Compound 4, a percentage reported as inhibition, in the whole organism at one dose (the size of the read-out at that dose, not a potency): 31.3%
Compound 4: the middle estimate sits 11.3 percentage points below what was measured; measured number inside the range.
By their numbers in this assay, from the lowest: compounds 1 and 3 (each within the scatter of the next); then compounds 2 and 4 (each within the scatter of the next).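

Isopropylamino in place of hydroxy on the carbonyl carbon gives a number 12.5 percentage points higher from compound 1 to compound 4 (beyond the scatter), so diethylamino is not the only group at this place that moves the number. The amide-type nitrogen also proves sensitive to the form of its chain: isopropyl in place of propyl gives a number 12.5 percentage points higher from compound 3 to compound 4 (beyond the scatter), while isopropylamino in place of diethylamino gives no change at the digits printed from compound 2 to compound 4 (within the scatter). Nothing available here explains these differences. As far as these compounds go, it remains open whether a tert-butyl or cyclopropyl group on the nitrogen would match isopropyl or propyl, and where an unsubstituted amino group would fall.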